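Iodo in place of chloro on compound 3

A few compounds are considered here, and "the series" means these few. Any claim that something is new, unique, unknown or untested is made for them only; others in the source may bear on it.

In a functional assay (strain AB) with Danio rerio as the target, read by microscopy, with a stated time of 1 h (a higher number here means that more compound is needed for the effect, a lower number that less compound is needed), three compounds on a shared core have been read. Compound 1 (`CCN1CCc2c(sc(NC(=O)Nc3cccc(Cl)c3Cl)c2C(N)=O)C1`) gives 17400 nM as its half-maximal effective concentration. Compound 2 (`CCN1CCc2c(sc(NC=O)c2C(N)=O)C1`) gives > 25000 nM and this is a limit of the assay. Compound 3 (`CCN1CCc2c(sc(NC(=O)Nc3ccc(Cl)cc3)c2C(N)=O)C1`) gives 3120 nM and so holds the lower of the two actual numbers. Compound 4 (`CCN1CCc2c(sc(NC(=O)Nc3ccc(I)cc3)c2C(N)=O)C1`) departs from compound 3 at one place: iodo in place of chloro on an aromatic carbon with iodo in place of chloro on an aromatic carbon, para to a large group. Within the data shown here, two measured steps touch this part of the structure. Putting 4-chlorophenyl in place of 2,3-dichlorophenyl gave a 5.6-fold lower number from compound 1 to compound 3 (0.75 log units; beyond the scatter) and putting (4-chlorophenyl)amino in place of hydrogen on a carbonyl carbon gave an at least 8.0-fold lower number from compound 2 to compound 3 (0.90 log units; beyond the scatter) as the second. Neither step exchanges one halogen alone, so no step beyond the scatter is expected, although the size of a 5.6-fold lower number from compound 1 to compound 3 (0.75 log units; beyond the scatter) argues for a wide range. The expected change is a 1.1-fold lower number from compound 3 to compound 4 (0.05 log units; within the scatter) in this assay and it is estimated to stay within the scatter. The value expected for compound 4 is 2800 nM with a range from 900 nM to 8500 nM as the estimate.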

Compound 4, half-maximal effective concentration: 1620 nM
Estimate against measurement, compound 4: 1.7-fold (0.24 log units) above, within the range that was stated.
By their numbers in this assay, from the lowest: compounds 4 and 3 (each within the scatter of the next); then compound 1. At a limit, above all of these: compound 2.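

In this assay, among these compounds, iodo in place of chloro on the aromatic carbon gives a 1.9-fold lower number from compound 3 to compound 4 (0.28 log units; within the scatter) and so leaves the two halogens at this place not separated, which the earlier compounds could not show. The difference from the 2,3-dichlorophenyl compound carries over to the new halogen, with 4-iodophenyl in its place giving an 11-fold lower number from compound 1 to compound 4 (1.03 log units; beyond the scatter) in this assay. The (4-iodophenyl)amino group on the carbonyl carbon gives an at least 15-fold lower number from compound 2 to compound 4 (1.18 log units; beyond the scatter) and this step has an open end, as compound 2 is a limit of the assay: the limit of > 25000 nM in this assay, at which 1 of the 4 values shown sits.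

The compounds shown leave open how fluoro or bromo would read at this place. They also leave open whether a group other than a halogen, such as an amine, a carboxylic acid or a longer chain, would be accepted there.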